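The source may report more compounds than this note shows. Statements on the series, on what has been measured and on what is new or still open speak of the compounds shown alone.

Measured compounds:
compound 1 `COc1ccc(-c2nn(-c3ccccc3)c(-c3ccc(C)cc3)c2S(=O)(=O)CC2=NCCS2)cc1` – "not active" (no number reported)
compound 2 `Cc1ccc(C2CNN=C2S(=O)(=O)CC2=NCCS2)cc1` – 43.1%
compound 3 `O=S(=O)(CC1=NCCS1)C1C(c2ccc(Cl)cc2)=NN(c2ccccc2)C1c1ccc(Cl)cc1` – "not active" (no number reported)

For the measured compounds named here, in a functional assay, read by Griess assay, with a stated time of 150 min, tested at 50 ug/mL (a higher number here means a stronger effect of the compound at the concentration tested, a lower number a weaker effect), compound 2 gives 43.1% and is the only compound of the three with a number reported. Going by the values given here, compound 1 and compound 3 are recorded as not active in this assay without a number, so no step to compound 2 can be computed for either, and nothing beyond the bare readings can be said of them.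

Compound 4 `Cc1ccc(C2CNN=C2S(=O)(=O)CC2=NCCO2)cc1` has not yet been measured. Relative to compound 2 the change is a group of 5 heavy atoms (3 carbon, 1 nitrogen, 1 oxygen; one five-membered non-aromatic ring with 2 hetero atoms) in place of a group of 5 heavy atoms (3 carbon, 1 nitrogen, 1 sulfur; one five-membered non-aromatic ring with 2 hetero atoms), on a saturated chain carbon bound to a sulfonyl sulfur. The shared core of compound 2 and compound 4 is otherwise unchanged, and the substituted aromatic ring on that core is the same in both.

Among the compounds with values here, no step between two measured compounds is available, so the size of the step to compound 4 rests on the change alone. The expectation is a small step in this assay, if any, likely downward but not clearly beyond the scatter of repeated measurements. Because compound 2 gives 43.1%, compound 4 is expected to remain in the same region of activity.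

For compound 4 the estimate in this assay is 36%, with a range from 15% to 55%. This estimate means an expected step of a number 7.1 percentage points lower from compound 2 to compound 4 (within the scatter).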

Compound 4, a percentage reported as activity, at one concentration (the size of the read-out at that concentration, not a potency): 45.9%
Compound 4: the middle estimate sits 9.9 percentage points below what was measured; the range from low to high includes it.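

In this assay, for the compounds shown here, exchanging sulfur for oxygen in the five-membered non-aromatic ring with 2 hetero atoms, on a saturated chain carbon bound to a sulfonyl sulfur, gives a number 2.8 percentage points higher from compound 2 to compound 4 (within the scatter); this is the first step that can be read, since steps to the compounds recorded without a number cannot be read. At this position, then, the read-out of the shared core survives this one exchange, and the two ring versions cannot be told apart in this assay. No measurement shown here bears on what lies behind this result.

This single exchange keeps the ring size and the counted atoms otherwise the same, so it says little about how much change the position can take, and whether the ring itself is needed remains unsettled. An open amine, a carboxylic acid or a longer chain on the same saturated chain carbon would test whether the read-out depends on the ring at all.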